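A methoxy group added to compound 2

The source may report more compounds than this note shows. Statements on the series, on what has been measured and on what is new or still open speak of the compounds shown alone.

Compound 1 `CCCOC(=O)N1N=C(c2ccccc2)CC1c1cc(OC)c(OC)c(OC)c1` gives > 10000 nM
Compound 2 `COc1cc(C2CC(c3ccccc3)=NN2C(=O)OCc2ccccc2)cc(OC)c1OC` gives > 10000 nM

Both entries come from a functional assay on A549 cells (Homo sapiens) for antiproliferative activity, read by MTT assay, with a stated time of 48 h (a lower number here means a stronger inhibitor of growth, a higher number a weaker inhibitor of growth), and each is a limit of the assay, not a number. Compound 2 therefore has no exact position (> 10000 nM). The whole picture so far is the limit of > 10000 nM in this assay, at which 2 of the 2 values shown sit. Among the measured compounds shown here, the only measured step (a step that the two limits leave unreadable from compound 1 to compound 2) has no readable size, and it lies elsewhere in the molecule.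

Compound 3 `COc1ccc(C2=NN(C(=O)OCc3ccccc3)C(c3cc(OC)c(OC)c(OC)c3)C2)cc1` differs from compound 2 by methoxy in place of hydrogen on an aromatic carbon. This is methoxy in place of hydrogen on an aromatic carbon, or phenyl to 4-methoxyphenyl. For the measured compounds named here, no measured step speaks to this change, so no size or direction can be expected beyond the scatter in this assay. The expected change is a step that the limit leaves unreadable from compound 2 to compound 3. For compound 3 the estimated value is 12000 nM (expected range 3000 nM to 30000 nM).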

Compound 3, concentration for 50% growth inhibition: > 10000 nM
Compound 3: no number, only a limit; the forecaster's own chance of this, stated with the estimate: 70%; the middle value does not contradict the limit.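

Compound 3 gives > 10000 nM, which is a limit of the assay and not a number. Compound 2 is also held at a limit, so no step can be read between these two compounds. The compounds shown leave open whether any change to the shared core brings growth inhibition into a measurable range: the limit of > 10000 nM in this assay, at which 3 of the 3 values shown sit.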